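The source may report more compounds than this note shows. Statements on the series, on what has been measured and on what is new or still open speak of the compounds shown alone.

The series rests on a shared core carrying an aryl urea, and the account follows one change to the group on the urea's methylene side. Compound 1 `CCOC(=O)c1ccc(NC(=O)NCc2cocn2)cc1` gives 27600 nM in an assay on isolated protein for activation of Nicotinamide phosphoribosyltransferase (Homo sapiens) (a lower number here means that less compound is needed, a higher number that more compound is needed for the effect), which is the highest of the three numbers recorded, and both of the others lie beyond the scatter from it. Compound 2 `O=C(NCc1ccncc1)Nc1ccc(S(=O)(=O)NCc2ccccc2)cc1` gives 102 nM, and compound 3 `O=C(NCc1ccncc1)Nc1ccc(S(=O)(=O)c2ccccc2Cl)cc1` gives 79 nM. Going by the values given here, the single measured step, a 1.3-fold lower number from compound 2 to compound 3 (0.11 log units; within the scatter), concerns a different part of the molecule from the one altered here and stays within the scatter.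

Compound 4 `CCOC(=O)c1ccc(NC(=O)NCc2cn[nH]c2)cc1` differs from compound 1 in one place: 1H-pyrazol-4-yl in place of 1,3-oxazol-4-yl on a saturated chain carbon bound to an amide-type nitrogen. Among the compounds with values here, no measured pair shows this exchange of one five-membered aromatic ring for another on the saturated chain carbon bound to the amide-type nitrogen, so there is no step in this assay that bears on it. Within the data shown here, the change keeps the size of the group and its placement, and the only step known in the set, from compound 2 to compound 3, was itself within the scatter. For compound 4 a shift of a 1.1-fold lower number from compound 1 to compound 4 (0.04 log units; within the scatter) is therefore expected, which amounts to no change beyond the scatter. Compound 4 is estimated at 25000 nM, with a range from 9000 nM to 70000 nM.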

Compound 4, half-maximal effective concentration: 1850 nM
For compound 4 the middle estimate is 14-fold (1.13 log units) above the measured one; measured number below the stated range.
By their numbers in this assay, from the lowest: compounds 3 and 2 (each within the scatter of the next); then compound 4; then compound 1.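

Going by these compounds alone, with a 15-fold lower number from compound 1 to compound 4 (1.17 log units; beyond the scatter) in this assay, the exchange gives the first step in the set that lies beyond the scatter between compounds differing in one place, since the only earlier step concerned another part of the molecule and stayed within the scatter. It shows that this place, on a saturated chain carbon bound to an amide-type nitrogen, distinguishes between two five-membered aromatic rings that match in their 5 heavy atoms and 2 hetero atoms, and differ in that 1H-pyrazol-4-yl has 2 nitrogen and no oxygen, with 1 hydrogen-bond donor and 1 hydrogen-bond acceptor, against 0 donors and 2 acceptors for 1,3-oxazol-4-yl. Nothing at hand accounts for why this exchange gives a step of this size.

The compounds shown cannot separate the contribution of the hydrogen-bond donor from that of the other differences between the two rings, which a comparison with 1-methyl-1H-pyrazol-4-yl or 1H-imidazol-4-yl at this place could address. Going by these compounds, whether the same exchange gives a similar step on another core, such as that of compound 2, also remains open.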